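Amide Ring Size and the Expected Potency of Compound 4

This account rests on a few compounds, and the source may have more. Where it says the series, first, only, none or still open, it means among the compounds named here.

Compound 3 `CC1CC(C(=O)N2CCc3nc(C#Cc4ccccc4)sc3C2)C1` carries a (3-methylcyclobutyl)carbonyl on the ring amine nitrogen of the shared core. In an assay on HEK293 cells for negative allosteric modulation of metabotropic glutamate receptor 5 (Homo sapiens), read by FLIPR, with a stated time of 1 h (a higher number here means a weaker inhibitor, a lower number a stronger inhibitor), compound 3 reaches only the limit of the assay, > 10000 nM, so no number is known for it; this is the limit of > 10000 nM in this assay, at which 1 of the 3 values shown sits. Compound 4 `O=C(C1CCCC1)N1CCc2nc(C#Cc3ccccc3)sc2C1` differs by cyclopentyl in place of 3-methylcyclobutyl on a carbonyl carbon. Going by the values given here, two measured steps bear on this change: from compound 2 `O=C(C1CC1)N1CCc2nc(C#Cc3ccccc3)sc2C1`, which gives 290 nM, the move to the larger ring gave an at least 34-fold higher number from compound 2 to compound 3 (1.53 log units; beyond the scatter), and from compound 1 `CC(C)CN1CCc2nc(C#Cc3ccccc3)sc2C1`, which gives 650 nM, it gave an at least 15-fold higher number from compound 1 to compound 3 (1.18 log units; beyond the scatter); the modest step of a 2.2-fold lower number from compound 1 to compound 2 (0.35 log units; beyond the scatter) separates those two starting points. Compound 4 keeps a ring of the same size, so the expected step of an at least 1.4-fold lower number from compound 3 to compound 4 (0.15 log units; that floor lies within the scatter) is small. Compound 4 is therefore estimated at 7000 nM, with a range from 1500 nM to 20000 nM.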

Compound 4, half-maximal inhibitory concentration: > 10000 nM
Compound 4: only a limit was reported (the forecaster's own chance of this, stated with the estimate: 50%); at least 1.4-fold (0.15 log units) between middle value and limit.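

Replacing the 3-methylcyclobutyl of compound 3 with cyclopentyl still gives no number in this assay, and compound 4 reaches only a limit, > 10000 nM. Among the amides shown, only cyclopropyl has a readable value, with an at least 34-fold higher number from compound 2 to compound 4 (1.53 log units; beyond the scatter) and, against the isobutyl amine, an at least 15-fold higher number from compound 1 to compound 4 (1.18 log units; beyond the scatter). No step can be read from compound 3 to compound 4, so these two groups cannot be ranked: the limit of > 10000 nM in this assay, at which 2 of the 4 values shown sit. Still open, from the compounds shown here alone, is whether cyclobutyl without the methyl, or a short chain such as ethyl, on the carbonyl carbon would give a readable value.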